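Naphthyl anilide variant of the tetrafluorophenoxy ketone series

The compounds below may be only part of what the source reports. "The series", "measured", "known", "first", "only" and "open" are said of these compounds alone.

Compound 1 `C[C@H](NC(=O)C(=O)Nc1ccccc1F)C(=O)N[C@@H](CC(=O)O)C(=O)COc1c(F)c(F)cc(F)c1F` is the stronger of the two measured analogues: in a functional assay on THP-1 cells (Homo sapiens) for inhibition (a higher number here means a weaker inhibitor, a lower number a stronger inhibitor), compound 1 gives 160 nM. Compound 2 `C[C@H](NC(=O)C(=O)Nc1ccccc1Oc1ccccc1)C(=O)N[C@@H](CC(=O)O)C(=O)COc1c(F)c(F)cc(F)c1F` gives 800 nM, and the step of a 5.0-fold higher number from compound 1 to compound 2 (0.70 log units; beyond the scatter) comes from phenoxy in place of fluoro on an aromatic carbon.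

Compound 3 `C[C@H](NC(=O)C(=O)Nc1cccc2ccccc12)C(=O)N[C@@H](CC(=O)O)C(=O)COc1c(F)c(F)cc(F)c1F` differs from compound 1 by naphthalen-1-yl in place of 2-fluorophenyl on an amide-type nitrogen. Among the measured compounds shown here, the only measured step that bears on it, enlarging the anilide portion, is a 5.0-fold higher number from compound 1 to compound 2 (0.70 log units; beyond the scatter); the naphthyl change is of a different kind, a fused second ring rather than a pendant one, so that step is only a rough guide. A weakening in this assay is expected, smaller than that seen with compound 2, giving the estimated step of a 2.2-fold higher number from compound 1 to compound 3 (0.34 log units; beyond the scatter). Compound 3 is expected to give 350 nM, within a range of 120 nM to 1000 nM.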

Compound 3, half-maximal inhibitory concentration: 60 nM
The estimate for compound 3 lay 5.8-fold (0.77 log units) above the measured number, and the stated range ends above it.
By their numbers in this assay, from the lowest: compound 3; then compound 1; then compound 2.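

In this assay the amide-type nitrogen allows a change of aryl group to move the number in either direction: naphthalen-1-yl in place of 2-fluorophenyl gives a 2.7-fold lower number from compound 1 to compound 3 (0.43 log units; beyond the scatter) and thus reverses the direction of a 5.0-fold higher number from compound 1 to compound 2 (0.70 log units; beyond the scatter). Adding heavy atoms to the group on this nitrogen is therefore not in itself a loss, with compound 2 going one way and compound 3 the other. Nothing available explains the gain seen with naphthalen-1-yl.

As far as these compounds go, it remains open whether the gain depends on the attachment point of the fused ring system, as naphthalen-2-yl would test, or on its being all carbon, as a quinoline would test. Also open, from the compounds shown here alone, is whether a fluoro group on naphthalen-1-yl would shift the number further.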